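A few compounds are considered here, and "the series" means these few. Any claim that something is new, unique, unknown or untested is made for them only; others in the source may bear on it.

Measured so far in an ADME assay on microsomes from liver (Homo sapiens) for metabolic stability, read by LC-MS, with a stated time of 30 min, tested at 1 uM; a higher number here means faster removal of the compound, a lower number slower removal:
compound 1 `Fc1ccc(-c2ccc3nnc(Cc4ccc5ncccc5c4)n3n2)cc1F`: 13.4 mL.min-1.g-1
compound 2 `C[C@@H](c1c[nH]c2ncccc12)c1nnc2ccc(-c3ccc(C#N)cc3)nn12`: 28 mL.min-1.g-1
compound 3 `COc1ccc(-c2ccc3nnc([C@@H](C)c4ccc5ncccc5c4)n3n2)cc1C`: 304 mL.min-1.g-1

Compound 3 stands highest of these three numbers, and its gaps to compound 2 and to compound 1 both lie beyond the scatter. The next compound is compound 4 `CNC(=O)c1ccc(-c2ccc3nnc([C@@H](C)c4ccc5ncccc5c4)n3n2)cc1`, which carries 4-(methylcarbamoyl)phenyl in place of the 4-methoxy-3-methylphenyl of compound 3, on an aromatic carbon of the shared core: 4-(methylcarbamoyl)phenyl in place of 4-methoxy-3-methylphenyl on an aromatic carbon.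

Within the data shown here, no measured pair differs in one place only, so this change has no direct precedent. Compound 1 and compound 2 also differ from compound 3 elsewhere, which makes them loose guides. Even so, compound 3 at 304 mL.min-1.g-1 sits far above both, so a move towards them is expected in this assay. The expected change, a 7.6-fold lower number from compound 3 to compound 4 (0.88 log units; beyond the scatter), is a fall beyond the scatter. For compound 4 the estimated value is 40 mL.min-1.g-1, with an expected range of 12 mL.min-1.g-1 to 130 mL.min-1.g-1.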

Compound 4, intrinsic clearance in microsomes: 12.2 mL.min-1.g-1
Compound 4: the middle estimate sits 3.3-fold (0.52 log units) above what was measured; the range from low to high includes it.
By their numbers in this assay, from the lowest: compounds 4 and 1 (each within the scatter of the next); then compound 2; then compound 3.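

In this assay, the series now has its first pair differing in one place, and this aromatic carbon of the shared core proves highly sensitive to the group it carries. Replacing 4-methoxy-3-methylphenyl with 4-(methylcarbamoyl)phenyl gives a 25-fold lower number from compound 3 to compound 4 (1.40 log units; beyond the scatter), a large step that arises with the rest of the structure unchanged and the six-membered aromatic ring of the group retained. Nothing available explains why the number falls so far.

This single pair cannot separate the loss of the methoxy and methyl groups from the gain of the methylcarbamoyl group. Also open, from the compounds shown here alone, is whether a primary carboxamide, a dimethylcarbamoyl group or a carboxylic acid on the same phenyl ring would give a similarly low number in this assay.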